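Trifluoromethyl for methyl on the aryl ring of compound 2

The compounds below may be only part of what the source reports. "The series", "measured", "known", "first", "only" and "open" are said of these compounds alone.

Compound 1 `COc1ccc2ccc(=O)oc2c1C1=NNC(c2ccc(C)cc2)C1` gives 43 nM in a functional assay on HepG2 cells (Homo sapiens) for cytotoxicity, read by MTT assay, with a stated time of 72 h; a higher number here means a weaker inhibitor, a lower number a stronger inhibitor.
Compound 2 `COc1ccc2ccc(=O)oc2c1C1=NN(c2ccccc2)C(c2ccc(C)cc2)C1` gives 51 nM in this assay.
Compound 3 `COc1ccc2ccc(=O)oc2c1C1=NN(C(C)=O)C(c2ccc(C)cc2)C1` gives 50 nM in this assay.

The three measured compounds share one core and differ only at the ring nitrogen. The step from the hydrogen of compound 1 to the phenyl of compound 2 reads a 1.2-fold higher number from compound 1 to compound 2 (0.07 log units; within the scatter), the step to the acetyl of compound 3 reads a 1.2-fold higher number from compound 1 to compound 3 (0.07 log units; within the scatter), and the step between phenyl and acetyl reads a 1.0-fold lower number from compound 2 to compound 3 (0.01 log units; within the scatter). Compound 2 therefore sits within the scatter of both companions; nothing among these numbers sets it apart.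

Compound 4 `COc1ccc2ccc(=O)oc2c1C1=NN(c2ccccc2)C(c2ccc(C(F)(F)F)cc2)C1` is compound 2 with one change: trifluoromethyl in place of methyl on an aromatic carbon. Among the compounds with values here, no measured step concerns this position; all three known steps touch the ring nitrogen, and each lies within the scatter. The data thus give no ground for expecting a shift in this assay beyond the scatter, in either direction. On that basis compound 4 is expected to give about 55 nM, within a range from 22 nM to 140 nM. The step expected from compound 2 to compound 4 is accordingly a 1.1-fold higher number from compound 2 to compound 4 (0.03 log units; within the scatter), an estimate rather than a measurement.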

Compound 4, half-maximal inhibitory concentration: 38 nM
The estimate for compound 4 lay 1.4-fold (0.16 log units) above the measured number; low and high end bracket the measured number.
By their numbers in this assay, from the lowest: compounds 4, 1, 3 and 2 (each within the scatter of the next).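

Of the steps shown, this is the only one that lies away from the ring nitrogen, and it extends the picture to the aromatic carbon para to a large group: in this assay, trifluoromethyl in place of methyl there reads a 1.3-fold lower number from compound 2 to compound 4 (0.13 log units; within the scatter). The exchange of a group of 1 heavy atom for one of 4 heavy atoms thus stays within the scatter at this place, as every change at the ring nitrogen did, so the aryl ring has so far shown no more of a step than the ring nitrogen. Nothing available explains this reading or speaks to what either group does here.

The compounds shown leave open whether a group of another kind at this place, such as an amine, a carboxylic acid or a longer chain, would also stay within the scatter. They also leave open whether the same exchange would read alike with hydrogen or acetyl on the ring nitrogen, as in compound 1 and compound 3, for trifluoromethyl appears here only with phenyl on that nitrogen.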